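The source may hold more compounds than are shown below. What is called first, only, known or untested is meant among the compounds shown, and "the series" means these compounds.

Two chalcone-like compounds that share a pyrazole-bearing core have been tested in a functional assay on KM12 cells (Homo sapiens) for cytotoxicity, read by sulforhodamine B assay, with a stated time of 48 h, tested at 0.01 uM; on this read-out higher numbers stand for a weaker effect at the one concentration tested and lower numbers for a stronger effect. Compound 1, `COc1cc(-c2cc(/C=C/C(=O)c3ccc(N)cc3)[nH]n2)cc(OC)c1OC`, carries a 4-aminophenyl on its carbonyl carbon, and in this assay compound 1 gives 102%. Compound 2, `COc1ccc(-c2cc(/C=C/C(=O)c3ccc(OC)c(OC)c3)[nH]n2)cc1`, is the closest companion on the numbers: in this assay compound 2 gives 105%. The two values sit within the usual scatter of each other, so compound 1 cannot be set apart from compound 2 on this read-out; both point to a negligible effect at the single concentration examined.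

Compound 3, `COc1cc(-c2cc(/C=C/C(=O)c3ccc(Cl)c(Cl)c3)[nH]n2)cc(OC)c1OC`, has not yet been measured. It is related to compound 1 by one change, (3,4-dichlorophenyl in place of 4-aminophenyl on a carbonyl carbon). Within the data shown here, no step between two measured compounds exists that would anchor this kind of change, so any expectation rests only on the values of compound 1 and compound 2. Given that compound 1 shows 102%, compound 3 is expected to remain near the same level, with the step of a number 2 percentage points lower from compound 1 to compound 3 (within the scatter) estimated to lie within the scatter. Compound 3 is therefore estimated at 100%, likely between 85% and 110%.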

Compound 3, a percentage reported as activity, at one concentration (the size of the read-out at that concentration, not a potency): 96%
Compound 3: the middle estimate sits 4 percentage points above what was measured; the range from low to high includes it.
By their numbers in this assay, from the lowest: compounds 3, 1 and 2 (each within the scatter of the next).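

Among these compounds, replacing 4-aminophenyl with 3,4-dichlorophenyl on a carbonyl carbon gives the first step that can be read at this position, and in this assay it is a number 6 percentage points lower from compound 1 to compound 3 (within the scatter) and so does not set the two compounds apart. The exchange is not a small one on paper: it takes away the hydrogen-bond donor and acceptor counted for 4-aminophenyl and brings in chlorine atoms with none of either, yet compound 3 gives 96% and this read-out at its one concentration does not register the difference. Nothing available explains this outcome or ties it to any feature of either group.

From the compounds shown here alone, whether this position is truly indifferent to its substituent, or whether the one concentration tested is simply too far from any effect for a difference to appear, remains open. It is also unknown whether a carboxylic acid, a dimethylamino group or a longer chain on that carbonyl carbon, in place of the aryl groups seen so far, would give a number beyond the scatter of compound 1.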